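Methoxy for Methyl on the Aryl Ring of Compound 2

A few compounds are considered here, and "the series" means these few. Any claim that something is new, unique, unknown or untested is made for them only; others in the source may bear on it.

Compound 1 `CCOC(=O)c1c(C)[nH]c(=O)c(C#N)c1-c1ccccc1` reaches only the limit > 100000 nM in a functional assay on A549 cells (Homo sapiens) for inhibition, read by MTT assay, with a stated time of 24 h; a higher number here means a weaker inhibitor, a lower number a stronger inhibitor. Compound 2 `CCOC(=O)c1c(C)[nH]c(=O)c(C#N)c1-c1ccc(C)cc1` gives 15900 nM in this assay, the only number shown. Among the measured compounds shown here, the step of an at least 6.2-fold lower number from compound 1 to compound 2 (0.79 log units; beyond the scatter) is the sole measured step, and the limit of > 100000 nM in this assay, at which 1 of the 2 values shown sits, shows it rests on a limit. Compound 3 `CCOC(=O)c1c(C)[nH]c(=O)c(C#N)c1-c1ccc(OC)cc1` differs from compound 2 by methoxy in place of methyl on an aromatic carbon. For the measured compounds named here, no measured step exchanges methyl for methoxy, so the expected step is a 1.1-fold lower number from compound 2 to compound 3 (0.03 log units; within the scatter) in this assay, within the scatter. Compound 3 is therefore estimated at 15000 nM, with a range from 4000 nM to 60000 nM.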

Compound 3, half-maximal inhibitory concentration: 25100 nM
Compound 3: middle estimate off by 1.7-fold (0.22 log units), on the low side; low and high end bracket the measured number.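

At the aromatic carbon para to a large group, methoxy in place of methyl gives a 1.6-fold higher number from compound 2 to compound 3 (0.20 log units; within the scatter) in this assay, so the two groups are not told apart here, although methoxy brings a hydrogen-bond acceptor. Methoxy in place of hydrogen gives an at least 3.9-fold lower number from compound 1 to compound 3 (0.60 log units; beyond the scatter), so both substituents shown at this carbon go with a lower number than hydrogen. The size of that step is only a bound, as compound 1 stands at a limit: the limit of > 100000 nM in this assay, at which 1 of the 3 values shown sits.

As far as these compounds go, how an amine, a carboxylic acid or a longer chain such as ethoxy would read at this carbon remains open. So does whether methoxy and methyl would stay equally close on other carbons of the ring.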